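A few compounds are considered here, and "the series" means these few. Any claim that something is new, unique, unknown or untested is made for them only; others in the source may bear on it.

Compounds 1 to 4 share one core and differ only in the two benzyl groups attached to it. Compound 1 `O=C1c2ccccc2N(Cc2ccccc2Cl)S(=O)(=O)N1Cc1ccccc1Cl` carries a chloro group on each benzyl arm, and compound 2 `O=C1c2ccccc2N(Cc2ccccc2)S(=O)(=O)N1Cc1ccccc1Cl` lacks one of them; the change from compound 1 to compound 2 is hydrogen in place of chloro on an aromatic carbon. In a functional assay on HEL cells (Homo sapiens) (a lower number here means that less compound is tolerated, a higher number that more compound is tolerated), compound 1 gives > 20000 nM, which is a limit of the assay and not a number. In this assay compound 2 gives 200000 nM. The step that the limit leaves unreadable from compound 1 to compound 2 cannot be sized because compound 1 sits at the limit of > 20000 nM in this assay, at which 1 of the 3 values shown sits.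

Compound 3 `O=C1c2ccccc2N(Cc2ccc(Cl)cc2)S(=O)(=O)N1Cc1ccc(Cl)cc1` again carries two chloro groups, and compound 4 `O=C1c2ccccc2N(Cc2ccc(Cl)cc2)S(=O)(=O)N1Cc1ccccc1` lacks one of them. The difference between the cores of compound 1 and compound 3 is not broken down here. In this assay compound 3 gives > 50000 nM, which is a limit and not a number, so compound 3 sits at the limit of > 50000 nM in this assay, at which 1 of the 3 values shown sits.

The change from compound 3 to compound 4 is hydrogen in place of chloro on an aromatic carbon. It is the same kind of change as that from compound 1 to compound 2, but not the same: in compound 1 the leaving chloro sits ortho to a large group, in compound 3 it sits para to a large group. For compound 4 a step that the limit leaves unreadable from compound 3 to compound 4 from compound 3 is estimated. This expectation rests on compound 2, which gives 200000 nM after the same kind of change. Compound 4 is expected to give about 150000 nM, within a range from 50000 nM to 400000 nM, though the assay may again return only a limit.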

Compound 4, minimum cytotoxic concentration: > 5000 nM
Compound 4 was reported as a limit (the forecaster's own chance of this, stated with the estimate: 40%); the middle value lies beyond the limit too.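

In this assay compound 4 gives > 5000 nM, which is a limit of the assay and not a number. Compound 3 is also reported only as a limit, and the step between compound 3 and compound 4 cannot be read. The compounds shown leave open how far hydrogen in place of chloro shifts the result in this assay, whether going from compound 1 to compound 2 or from compound 3 to compound 4.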